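From acetyl to methoxycarbonyl on the shared core

The source may report more compounds than this note shows. Statements on the series, on what has been measured and on what is new or still open speak of the compounds shown alone.

Compound 3 `CC(=O)NCC#CCn1cncc1C` gives > 100 mg/kg in a functional assay on the whole organism for agonist activity, with Mus musculus as the target (a lower number here means that less compound is needed, a higher number that more compound is needed for the effect), which is a limit and not a number. Compound 1 `CC(=O)N(C)C(C)C#CCn1ccnc1C` gives > 100 mg/kg, again a limit. Compound 2 `CC(=O)NCC#CCn1ccnc1` gives > 100 mg/kg, also a limit. Among the compounds with values here, the series so far therefore offers no numerical reading, only (the limit of > 100 mg/kg in this assay, at which 3 of the 3 values shown sit).

Compound 4 `COC(=O)NCC#CCn1cncc1C` carries methoxy in place of methyl on a carbonyl carbon. The same difference, cut one bond further out, reads acetamido to (methoxycarbonyl)amino.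

Within the data shown here, the only measured step is a step that the two limits leave unreadable from compound 2 to compound 3, and it is a different change, methyl in place of hydrogen on an aromatic carbon. It gives no size or direction for the change at the carbonyl carbon. Among the measured compounds shown here, no measured step covers that change, so no shift beyond the scatter is expected in this assay. The expected step, a step that the limit leaves unreadable from compound 3 to compound 4, is only a rough estimate, and it rests on the limit of compound 3 at > 100 mg/kg. Another reading at the limit is the likeliest outcome. The estimate for compound 4 is 150 mg/kg, with an expected range from 50 mg/kg to 400 mg/kg.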

Compound 4, dose for half-maximal effect: > 100 mg/kg
Compound 4 gave a limit, no number; the forecaster's own chance of this, stated with the estimate: 75%; the middle value is on the limit's open side.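

In this assay compound 4 gives > 100 mg/kg as a limit and not a number, so no new step can be read from compound 3 to compound 4, and all readings remain at one limit: the limit of > 100 mg/kg in this assay, at which 4 of the 4 values shown sit.

The compounds shown leave open whether any change on the shared core gives a readable number in this assay at all.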